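The source may hold more compounds than are shown below. What is called first, only, known or untested is meant among the compounds shown, and "the series" means these compounds.

Going by the values given here, compound 3 `CCOc1c(-c2occ(C)c2CO)ccc2c(CC)cccc12` is the only compound of the three with a number in a functional assay on MDA-MB-231 cells (Homo sapiens) for cytotoxicity, read by MTT assay, with a stated time of 72 h (on this read-out lower numbers stand for an effect already at smaller amounts and higher numbers for an effect only at larger amounts of compound), where compound 3 gives 1.4 ug/mL. Compound 1 `CCc1cccc2c(OC)c(-c3occ(C)c3C(=O)NC)ccc12` reaches only a limit of this assay, > 10 ug/mL. Compound 2 `CCc1cccc2c(OC)c(-c3occ(C)c3CO)ccc12` likewise sits at a limit, > 10 ug/mL. Hence a step that the two limits leave unreadable from compound 1 to compound 2, whereas an at least 7.1-fold lower number from compound 2 to compound 3 (0.85 log units; beyond the scatter), the one readable step, consistent with the limit of > 10 ug/mL in this assay, at which 2 of the 3 values shown sit. Compound 4 `CCOc1c(-c2occ(C)c2COC(C)=O)ccc2c(CC)cccc12` differs from compound 3 by acetyl in place of hydrogen on an oxygen on a saturated carbon. Among the compounds with values here, no measured step touches this oxygen; the only step at the hydroxymethyl group is the unreadable one, so no direction is given. Compound 4 is therefore expected to stay close to compound 3, with a 1.1-fold higher number from compound 3 to compound 4 (0.06 log units; within the scatter). The estimate for compound 4 is 1.6 ug/mL, within a range from 0.6 ug/mL to 4.5 ug/mL.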

Compound 4, concentration for half-maximal effect: 4.9 ug/mL
For compound 4 the middle estimate is 3.1-fold (0.49 log units) below the measured one; the measured number lies above the stated range.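

On the hydroxymethyl group, which had offered only an unreadable step, the change to acetoxymethyl gives the first readable result: in this assay there is a 3.5-fold higher number from compound 3 to compound 4 (0.54 log units; beyond the scatter). This place therefore responds to substitution on its oxygen, yet a free hydroxy is not required for a number, as compound 4 stays measurable. Nothing in the data given accounts for the size of this step. Going by these compounds, it remains open whether a propionyl group or an amine in place of the hydroxy would shift the number in the same direction.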